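Chloro in Place of Isopropyl on a Shared Core

A few compounds are considered here, and "the series" means these few. Any claim that something is new, unique, unknown or untested is made for them only; others in the source may bear on it.

Compound 1 `Cc1ccc(Cn2cc(CSc3nc(Nc4ccccc4F)c(C#N)c(-c4ccccc4)n3)nn2)cc1` in a functional assay on ECa-109 cells (Homo sapiens) for inhibition, read by MTT assay, with a stated time of 72 h (on this read-out lower numbers stand for stronger inhibition and higher numbers for weaker inhibition), is recorded only as a limit, > 64000 nM.
Compound 2 `Cc1ccc(Nc2nc(SCc3cn(Cc4ccccc4Cl)nn3)nc(-c3ccc(C(C)C)cc3)c2C#N)cc1` in this assay gives 5080 nM.
Compound 3 `COc1ccc(Nc2nc(SCc3cn(Cc4ccccc4Cl)nn3)nc(-c3ccc(C(C)C)cc3)c2C#N)cc1` in this assay gives 3580 nM.

Among the two numbers that are not limits, compound 2 has the higher one, and its nearest neighbour is compound 3, reached by a 1.4-fold lower number from compound 2 to compound 3 (0.15 log units; within the scatter), a change of methoxy for methyl on an aromatic carbon. Among the compounds with values here, compound 1 sits at the limit of > 64000 nM in this assay, at which 1 of the 3 values shown sits, and differs from compound 2 in several places at once, so it yields no single step.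

Compound 4 `Cc1ccc(Nc2nc(SCc3cn(Cc4ccccc4Cl)nn3)nc(-c3ccc(Cl)cc3)c2C#N)cc1` differs from compound 2 by chloro in place of isopropyl on an aromatic carbon. Within the data shown here, no measured step touches the group on that ring: the only step recorded, from compound 2 to compound 3, lies elsewhere on the core and stays within the scatter. There is therefore nothing in the data that would predict a shift beyond the scatter in this assay for this change, in either direction, and the estimate must carry a wide range.

For compound 4 the expected step is a 1.2-fold higher number from compound 2 to compound 4 (0.07 log units; within the scatter). Compound 4 is estimated at 6000 nM, within 2000 nM to 20000 nM.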

Compound 4, half-maximal inhibitory concentration: 7540 nM
Compound 4: middle estimate off by 1.3-fold (0.10 log units), on the low side, within the range that was stated.
By their numbers in this assay, from the lowest: compounds 3, 2 and 4 (each within the scatter of the next, the first and the last beyond it). At a limit, above all of these: compound 1.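

Within the data shown here, compounds 2 and 3 both carry the 4-isopropylphenyl group, so neither could say anything about the group on that ring, and the only earlier step lay elsewhere on the shared core. In this assay, among these compounds, this change gives the first reading at that place, on an aromatic carbon para to a large group, as a 1.5-fold higher number from compound 2 to compound 4 (0.17 log units; within the scatter). Going from isopropyl, with 3 heavy atoms, to chloro, with 1 heavy atom, therefore leaves the read-out within the usual scatter for this one pair, so this swap on the 4-isopropylphenyl to 4-chlorophenyl line neither gains nor loses anything that can be told apart from repeat measurements, and nothing shown here accounts for the size of the step.

Whether an amine, a carboxylic acid or a longer alkyl chain at the same place on this ring would also stay within the scatter remains open, since chloro and isopropyl are the only two groups seen there among these compounds. Also open, from the compounds shown here alone, is whether the same swap would behave the same way on compound 3, which carries methoxy in place of methyl.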